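This account rests on a few compounds, and the source may have more. Where it says the series, first, only, none or still open, it means among the compounds named here.

Values in a physicochemical assay for solubility, using the shake flask method, measured as kinetic solubility, with a stated time of 20 h, at pH 2; on this read-out higher numbers stand for higher solubility and lower numbers for lower solubility:
- compound 1 `FC(F)(F)c1cccc(-c2nc3cnc(Nc4ncccn4)cc3[nH]2)c1`: 155000 nM
- compound 2 `FC(F)(F)c1ccc(Nc2cc3[nH]c(-c4cccc(C(F)(F)F)c4)nc3cn2)nc1`: < 5000 nM, a limit of the assay
- compound 3 `CN1CCN(c2ccc(Nc3cc4[nH]c(-c5cccc(C(F)(F)F)c5)nc4cn3)nc2)CC1`: 190000 nM

Compound 2 stands lowest of the three, and it is the only one known just as a limit (the limit of < 5000 nM in this assay, at which 1 of the 3 values shown sits). Compound 4 `FC(F)(F)c1ccc(Nc2cc3[nH]c(C4CCOCC4)nc3cn2)nc1` differs from it in one place oxan-4-yl in place of 3-(trifluoromethyl)phenyl on an aromatic carbon, on the five-membered aromatic ring with 2 nitrogen.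

Within the data shown here, no measured step changes that place, so the evidence is indirect. Among the measured compounds shown here, two steps bear on it, and both are large and beyond the scatter. The first is an at least 31-fold lower number from compound 1 to compound 2 (1.49 log units; beyond the scatter), with 5-(trifluoromethyl)pyridin-2-yl in place of pyrimidin-2-yl on a nitrogen on an aromatic ring. The second is an at least 38-fold higher number from compound 2 to compound 3 (1.57 log units; beyond the scatter), with 4-methylpiperazin-1-yl in place of trifluoromethyl on an aromatic carbon. Among these three compounds, the number is lower where a further trifluoromethyl is present, and no compound here goes against that. Compound 4 also gives up a trifluoromethyl, although it keeps the one on its pyridine, so a clear move to a higher number is expected, with less certainty than either measured step offers.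

The expected change is an at least 8.0-fold higher number from compound 2 to compound 4 (0.90 log units; beyond the scatter). For compound 4 the estimated value is 40000 nM, with an expected range of 7000 nM to 200000 nM.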

Compound 4, solubility: 196000 nM
The estimate for compound 4 lay 4.9-fold (0.69 log units) below the measured number, and the stated range covers the measured number.
By their numbers in this assay, from the lowest: compounds 1, 3 and 4 (each within the scatter of the next). At a limit, below all of these: compound 2.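

In this assay, this is the first change shown at the aromatic carbon between two ring nitrogen atoms, and oxan-4-yl in place of 3-(trifluoromethyl)phenyl at that place gives an at least 39-fold higher number from compound 2 to compound 4 (1.59 log units; beyond the scatter). Compound 2 is known only as a limit, so the step has a lower bound but no upper end: the limit of < 5000 nM in this assay, at which 1 of the 4 values shown sits. Among these compounds, compound 4 keeps the 5-(trifluoromethyl)pyridin-2-yl of compound 2, so that group does not by itself hold the number down, and a large step is now seen at this third place as well as at the two places changed in the earlier steps.

The step exchanges a whole group, so the compounds shown do not separate the loss of the trifluoromethyl from the loss of the aromatic ring or the arrival of the ring oxygen. From the compounds shown here alone, a plain phenyl, a cyclohexyl with no oxygen, or a piperidin-4-yl with its ring amine at this place would pull these apart, and whether oxan-4-yl gives a like step with pyrimidin-2-yl on the nitrogen also stays open.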